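The source may report more compounds than this note shows. Statements on the series, on what has been measured and on what is new or still open speak of the compounds shown alone.

In a physicochemical assay for lipophilicity, at pH 7.4 (on this read-out lower numbers stand for lower lipophilicity and higher numbers for higher lipophilicity), the measured compounds stand as follows: compound 1 `COc1cc(-c2nnc3n2CCCC3c2ccc(Cl)cc2)ccc1-c1cnc(C)o1`, 2.8; compound 2 `COc1cc(-c2nnc3n2CCCC3c2ccccc2C(F)(F)F)ccc1-c1cnc(C)o1`, 3; compound 3 `COc1cc(-c2nnc3n2CCCC3c2ccc(Cl)c(C(F)(F)F)c2)ccc1-c1cnc(C)o1`, 3.2.

The two cores differ by 2-(trifluoromethyl)phenyl in place of 4-chlorophenyl on a saturated ring carbon, and the measured step is a number 0.20 log units higher from compound 1 to compound 2 (within the scatter). Compound 3 arises from compound 1 through (trifluoromethyl in place of hydrogen on an aromatic carbon), which gave a number 0.40 log units higher from compound 1 to compound 3 (beyond the scatter).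

The unmeasured compound 4 `COc1cc(-c2nnc3n2CCCC3c2cc(C(F)(F)F)ccc2C(F)(F)F)ccc1-c1cnc(C)o1` arises from compound 2 through (trifluoromethyl in place of hydrogen on an aromatic carbon). This is the same kind of change, not the same one: in compound 1 the entering group sits ortho to a chloro group and meta to a large group, whereas in compound 2 it sits meta to a large group and para to a trifluoromethyl group. A step of similar size is expected, a number 0.40 log units higher from compound 2 to compound 4 (beyond the scatter), because the earlier step read a number 0.40 log units higher from compound 1 to compound 3 (beyond the scatter). Compound 4 is therefore estimated at 3.4, between 3 and 3.8.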

Compound 4, distribution coefficient: 3.3
For compound 4 the middle estimate is 0.10 log units above the measured one; the range from low to high includes it.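

In this assay, trifluoromethyl in place of hydrogen on an aromatic carbon gave a number 0.30 log units higher from compound 2 to compound 4 (within the scatter) on the core of compound 2, while the same kind of change on the core of compound 1 gave a number 0.40 log units higher from compound 1 to compound 3 (beyond the scatter). For the compounds shown here, the printed numbers therefore point the same way on both cores, but only the step on the core of compound 1 lies beyond the scatter, and two pairs, with the entering group at different places, do not establish a rule for the series. Nothing shown here explains the size of either step.

The compounds shown leave open whether the change would read alike on a third core. They also leave open how an amine or a carboxylic acid would read in place of that hydrogen, as the aryl groups shown carry only chloro and trifluoromethyl groups.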